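A Dimethyloxazole in Place of the Cyanophenyl Group

A few compounds are considered here, and "the series" means these few. Any claim that something is new, unique, unknown or untested is made for them only; others in the source may bear on it.

Measured in a functional assay on HEK293 cells for agonist activity at G-protein coupled receptor 39 (Homo sapiens), read by scintillation proximity assay and inositol phosphate accumulation, with a stated time of 75 min, in the presence of a further agent that is not named here; on this read-out lower numbers stand for an effect already at smaller amounts and higher numbers for an effect only at larger amounts of compound:
compound 1 `Cc1nn(-c2ncnc3nc[nH]c23)c2c1C(OCc1ccc(Cl)cc1Cl)CC(=O)N2` gives 4 nM
compound 2 `Cc1cc(C)n(CCOC2CC(=O)Nc3c2c(C)nn3-c2ncnc3nc[nH]c23)n1` gives 16 nM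
compound 3 `Cc1nn(-c2ncnc3nc[nH]c23)c2c1C(OCc1ccccc1C#N)CC(=O)N2` gives 8 nM

Compound 3 stands second highest of the three numbers, yet its gaps to compound 1 and to compound 2 both lie within the scatter, so no order among them is claimed. Compound 4 `Cc1noc(C)c1COC1CC(=O)Nc2c1c(C)nn2-c1ncnc2nc[nH]c12` differs from compound 3 in one place: 3,5-dimethyl-1,2-oxazol-4-yl in place of 2-cyanophenyl on a saturated chain carbon bound to an oxygen on a saturated carbon. Within the data shown here, two measured steps bear on this exchange of an aryl for a small heteroaryl at the same place: a 4.0-fold higher number from compound 1 to compound 2 (0.60 log units; beyond the scatter) and a 2.0-fold lower number from compound 2 to compound 3 (0.30 log units; within the scatter). The entering group resembles the (3,5-dimethyl-1H-pyrazol-1-yl)methyl group of compound 2 more than the 2-cyanophenyl of compound 3, and compound 2 gives 16 nM. For compound 4 a modest rise is therefore expected, a 1.8-fold higher number from compound 3 to compound 4 (0.24 log units; within the scatter). Compound 4 is estimated at 14 nM, within a range from 5 nM to 40 nM.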

Compound 4, half-maximal effective concentration: 5 nM
Beside the measured number, compound 4's estimate is 2.8-fold (0.45 log units) above it; the measured number falls inside the stated range.
By their numbers in this assay, from the lowest: compounds 1, 4, 3 and 2 (each within the scatter of the next, the first and the last beyond it).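

The oxygen-linked group need not be a benzene ring: a five-membered 3,5-dimethyl-1,2-oxazol-4-yl cannot be told apart from either benzene-bearing group, with a 1.6-fold lower number from compound 3 to compound 4 (0.20 log units; within the scatter) and a 1.3-fold higher number from compound 1 to compound 4 (0.10 log units; within the scatter). Nor do all small heteroaryl groups behave alike here, with a 3.2-fold lower number from compound 2 to compound 4 (0.51 log units; beyond the scatter). Nothing measured here explains that gap.

From the compounds shown here alone, all four compounds carry an aromatic ring at this place, so whether the ring is needed at all stays open. Going by these compounds, what an amine or a carboxylic acid would do there also remains unknown.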